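The compounds below may be only part of what the source reports. "The series", "measured", "known", "first", "only" and "open" are said of these compounds alone.

Measured in an assay on HEK293 cells for inhibition of N-acylethanolamine-hydrolyzing acid amidase (Homo sapiens), read by fluorescence, with stated times of 10 min and 50 min; a lower number here means a stronger inhibitor, a higher number a weaker inhibitor:
compound 1 `C[C@H]1[C@H](NC(=O)OCCCCC2CCCCC2)C(=O)N1OCCCS(C)(=O)=O` gives 49 nM
compound 2 `C[C@H]1[C@H](NC(=O)OCCCCC2CCCCC2)C(=O)N1OCCCCc1ccccc1` gives 1240 nM
compound 3 `C[C@H]1[C@H](NC(=O)OCCCCC2CCCCC2)C(=O)N1Oc1ccccc1` gives 23 nM

Compound 3 stands at the lowest number of the three, with a 2.1-fold lower number from compound 1 to compound 3 (0.33 log units; beyond the scatter) and a 54-fold lower number from compound 2 to compound 3 (1.73 log units; beyond the scatter) in this assay. Compound 4 `C[C@H]1[C@H](NC(=O)OCCCCC2CCCCC2)C(=O)N1Oc1ccc([N+](=O)[O-])cc1` differs from it by nitro in place of hydrogen on an aromatic carbon. Among the measured compounds shown here, no measured step changes a substituent on that ring: all three steps, including a 25-fold higher number from compound 1 to compound 2 (1.40 log units; beyond the scatter), swap the whole group on the oxygen, so they show only that the phenoxy compound holds the lowest number and say nothing direct about a nitro group. A step within the scatter, in no clear direction, is therefore expected for a 1.2-fold lower number from compound 3 to compound 4 (0.06 log units; within the scatter). Compound 4 is estimated at 20 nM, ranging from 6 nM to 70 nM.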

Compound 4, half-maximal inhibitory concentration: 17 nM
Compound 4: middle estimate off by 1.2-fold (0.07 log units), on the high side; measured number inside the range.
By their numbers in this assay, from the lowest: compounds 4 and 3 (each within the scatter of the next); then compound 1; then compound 2.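

In this assay, among the compounds shown here, the first change on the ring itself, nitro on the aromatic carbon para to a large group, gives a 1.4-fold lower number from compound 3 to compound 4 (0.13 log units; within the scatter), so phenoxy and 4-nitrophenoxy cannot be told apart here. With 4-nitrophenyl on the oxygen, the comparisons with the other groups stay beyond the scatter, with a 2.9-fold lower number from compound 1 to compound 4 (0.46 log units; beyond the scatter) and a 73-fold lower number from compound 2 to compound 4 (1.86 log units; beyond the scatter). Nothing available explains these steps. Going by these compounds, whether an amine, a carboxylic acid or a methoxy group on that same carbon would also stay within the scatter remains open.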